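The source may report more compounds than this note shows. Statements on the series, on what has been measured and on what is new or still open speak of the compounds shown alone.

Among the compounds with values here, in an assay on isolated protein for inhibition of thyroid hormone receptor beta (Homo sapiens), read by fluorescence, with a stated time of 30 min (a lower number here means a stronger inhibitor, a higher number a weaker inhibitor), compound 2 `COc1cc(C(=O)N2CCCC2(C)C)cc2nc(NCc3cccc(Cl)c3)oc12` gives 47 nM, the lowest of the two numbers measured so far. Compound 1 `O=C(NCc1cccc(Cl)c1)c1ccc2cn(CCN3CCOC3=O)nc2c1` gives 220 nM in this assay, a weaker result that lies beyond the usual scatter. Compound 3 `COc1cc(C(=O)N2CC(C)C(O)CC2CCO)cc2nc(NCc3cccc(Cl)c3)oc12` differs from compound 2 in one place: 4-hydroxy-2-(2-hydroxyethyl)-5-methylpiperidin-1-yl in place of 2,2-dimethylpyrrolidin-1-yl on a carbonyl carbon. Within the data shown here, no pair of measured compounds shows a change of this kind, so the expected step from compound 2 to compound 3 in this assay is uncertain; a modest loss, a 2.8-fold higher number from compound 2 to compound 3 (0.44 log units; beyond the scatter), is expected. Compound 3 is therefore estimated at 130 nM, with a likely range from 45 nM to 400 nM.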

Compound 3, half-maximal inhibitory concentration: 0.27 nM
Beside the measured number, compound 3's estimate is 480-fold (2.68 log units) above it; the whole stated range lies above it.
By their numbers in this assay, from the lowest: compound 3; then compound 2; then compound 1.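

In this assay, changing the group on a carbonyl carbon gives a 170-fold lower number from compound 2 to compound 3 (2.24 log units; beyond the scatter) when 4-hydroxy-2-(2-hydroxyethyl)-5-methylpiperidin-1-yl replaces 2,2-dimethylpyrrolidin-1-yl. This place therefore accepts a larger group with a six-membered ring and 2 hydrogen-bond donors, and the number still falls steeply. Nothing available here accounts for the size of this step.

Going by these compounds, all parts of the new group enter at once, so it remains open whether the 4-hydroxy, the 2-hydroxyethyl, the 5-methyl or the six-membered ring carries the step. On these data alone, whether an amine or a carboxylic acid could stand in place of a hydroxy also remains open.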